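The compounds below may be only part of what the source reports. "The series", "measured", "known", "first", "only" and "open" are said of these compounds alone.

In an ADME assay on RAW264.7 cells (Mus musculus) for cytotoxicity, read by MTT assay, with a stated time of 24 h, in the presence of a further agent that is not named here (a higher number here means a weaker inhibitor, a lower number a stronger inhibitor), compound 1 (`CCCCCCOc1ccc(C(O)C2OC(=O)c3c(OC)cc(OC)cc32)cc1`) gives > 40000 nM as a limit, not a number. Compound 2 (`CCC(C)Oc1ccc(C(O)C2OC(=O)c3c(OC)cc(OC)cc32)cc1`) likewise gives > 40000 nM as a limit. Compound 3 (`COCCOc1ccc(C(O)C2OC(=O)c3c(OC)cc(OC)cc32)cc1`) gives > 40000 nM as a limit as well, so it has no number of its own. It cannot be ranked against the other two, since the whole set rests on the limit of > 40000 nM in this assay, at which 3 of the 3 values shown sit, and on nothing finer.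

Compound 4 (`COc1cc(OC)c2c(c1)C(C(O)c1ccc(OCCOc3ccccc3)cc1)OC2=O`) departs from compound 3 at a single place, with phenyl in place of methyl on an oxygen on a saturated carbon, which reads as 2-methoxyethyl to 2-phenoxyethyl (phenyl in place of methyl on an oxygen on a saturated carbon) in the side chain.

The measured steps that bear on this change are those that also alter this chain, namely a step that the two limits leave unreadable from compound 1 to compound 3 and a step that the two limits leave unreadable from compound 2 to compound 3 as well as a step that the two limits leave unreadable from compound 1 to compound 2 in the same place. None of them has a readable size. Because a step that the two limits leave unreadable from compound 1 to compound 3 and a step that the two limits leave unreadable from compound 2 to compound 3 give no size, they offer no direction, and compound 4 is expected to stay at the limit of this assay rather than yield a number.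

The expected change is a step that the limit leaves unreadable from compound 3 to compound 4 with no direction beyond the scatter. For compound 4 the estimate is 55000 nM with an expected range from 22000 nM to 130000 nM in this reading.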

Compound 4, half-maximal inhibitory concentration: > 40000 nM
Compound 4: no number, only a limit; the forecaster's own chance of this, stated with the estimate: 85%; the middle value is on the limit's open side.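

In this assay compound 4 gives > 40000 nM, which is a limit and not a number. Its steps to compound 1, compound 2 and compound 3 therefore cannot be read: the limit of > 40000 nM in this assay, at which 4 of the 4 values shown sit.

The compounds shown leave open whether any of these side chains changes the result in this assay, and where the true values of the four compounds lie.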